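Lengthening the Chain: From Compound 2 to Compound 3

The compounds below may be only part of what the source reports. "The series", "measured", "known", "first", "only" and "open" are said of these compounds alone.

Compound 1 `CCCCCCCCCCCCCCNC(=O)[C@@H](NC(=O)c1ccccc1)[C@@H](C)O` and compound 2 `CCCCCCCCCCCCCCNC(=O)[C@@H](NC(=O)c1nccc2ccccc12)[C@@H](C)O` share one core and differ only in the aromatic group on the carbonyl carbon. In a functional assay on SW-620 cells (Homo sapiens) for cytotoxicity, read by MTT assay, with a stated time of 48 h (on this read-out higher numbers stand for weaker inhibition and lower numbers for stronger inhibition), compound 1 gives 200000 nM, while compound 2 gives 30400 nM; that change is a 6.6-fold lower number from compound 1 to compound 2 (0.82 log units; beyond the scatter). Compound 2 therefore stands at the lowest of the two numbers, the stronger inhibitor of the pair. Compound 3 `CCCCCCCCCCCCCCCCCCNC(=O)[C@@H](NC(=O)c1nccc2ccccc12)[C@@H](C)O` keeps everything in compound 2 and alters only the far end of the chain: butyl in place of hydrogen on a saturated chain carbon, ten or more bonds along the chain from an amide-type nitrogen. Going by the values given here, no measured step touches this part of the molecule; the single step on record concerns the aromatic group and says nothing about lengthening a saturated chain. Without such a guide, the expectation for compound 3 is a step of about a 1.0-fold lower number from compound 2 to compound 3 (0.01 log units; within the scatter) from compound 2, in no particular direction and not expected to exceed the scatter. Compound 3 is thus estimated at 30000 nM, within 10000 nM to 90000 nM.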

Compound 3, half-maximal inhibitory concentration: 136000 nM
Beside the measured number, compound 3's estimate is 4.5-fold (0.66 log units) below it; measured number outside the range, above it.
By their numbers in this assay, from the lowest: compound 2; then compounds 3 and 1 (each within the scatter of the next).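

The far end of the chain turns out not to be a silent part of the molecule: in this assay, butyl in place of hydrogen on a saturated chain carbon, ten or more bonds along the chain from an amide-type nitrogen, gives a 4.5-fold higher number from compound 2 to compound 3 (0.65 log units; beyond the scatter), a move toward weaker inhibition. Going by these compounds alone, this is the first measured step at this end of the molecule, and it shows that adding chain length here, with the isoquinolin-1-yl group kept in place, does not leave the number unchanged. The evidence at hand offers no explanation for this change.

As far as these compounds go, whether a shorter chain, such as a decyl chain, would give a lower number than compound 2 remains open. So does the outcome of ending the chain in an amine or a carboxylic acid, and whether the same lengthening would act alike with phenyl on the carbonyl carbon.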